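Swapping Isobutyl for Phenyl in Compound 2

The source may hold more compounds than are shown below. What is called first, only, known or untested is meant among the compounds shown, and "the series" means these compounds.

Of the compounds shown here, three have so far been tested in a functional assay on MCF7 cells (Homo sapiens) for cytotoxicity, read by MTT assay, with a stated time of 72 h; a lower number here means that less compound is tolerated, a higher number that more compound is tolerated. Compound 1 `CCOC(=O)Nc1ccc([Se][Se]c2ccc(NC(=O)OCC)cc2)cc1` gives 68300 nM, compound 2 `CC(C)COC(=O)Nc1ccc([Se]C#N)cc1` gives 73000 nM, and compound 3 `O=C(Nc1ccc([Se][Se]c2ccc(NC(=O)OCc3ccc([N+](=O)[O-])cc3)cc2)cc1)OCc1ccc([N+](=O)[O-])cc1` gives 85000 nM. Compound 2 holds the second highest of these three numbers, yet its gap to compound 1 and its gap to compound 3 both sit within the scatter of repeated measurements, so the three cannot be told apart. Compound 4 `N#C[Se]c1ccc(NC(=O)Oc2ccccc2)cc1` has not yet been measured. It differs from compound 2 in one place: phenyl in place of isobutyl on an oxygen next to a carbonyl group. Among the measured compounds shown here, no measured pair shows what such a change does, so no step beyond the scatter is expected in either direction. Compound 4 is expected to give about 70000 nM, with a likely range from 35000 nM to 140000 nM. That estimate means an expected step of a 1.0-fold lower number from compound 2 to compound 4 (0.02 log units; within the scatter).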

Compound 4, concentration lethal to 50% of the cells: 67800 nM
For compound 4 the middle estimate is 1.0-fold (0.01 log units) above the measured one, within the range that was stated.
By their numbers in this assay, from the lowest: compounds 4, 1, 2 and 3 (each within the scatter of the next).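

In this assay, among the compounds shown here, phenyl in place of isobutyl on an oxygen next to a carbonyl group gives a 1.1-fold lower number from compound 2 to compound 4 (0.03 log units; within the scatter) and is the first direct reading of this change. At this place, then, a six-membered aromatic ring of carbon only and an open isobutyl group cannot be told apart in this assay. No measured evidence is available that bears on this result.

As far as these compounds go, it remains open whether a group such as an amine, a carboxylic acid or a longer chain on this oxygen would move the number beyond the scatter. From the compounds shown here alone, whether phenyl would behave the same way on another core also remains open.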